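Swapping a Sulfur Side Chain for a Nitrogen-Rich One

The compounds below may be only part of what the source reports. "The series", "measured", "known", "first", "only" and "open" are said of these compounds alone.

Of the compounds shown here, two have been measured in a functional assay on the whole organism (Tail, strain ICR) with Mus musculus as the target, in the tail flick test, with a stated time of 120 min, at a dose of 25 umol/kg by the oral route; a higher number here means a stronger effect of the compound at the dose given, a lower number a weaker effect. Compound 1, `N=C(N)NCCC[C@H](NC(=O)CN(c1ncnc2c1ncn2C1CCCCO1)C1CC1)C(=O)OCc1ccccc1`, gives 38.2% in this assay. Compound 2, `CSCC[C@H](NC(=O)CN(c1nc(Cl)nc2[nH]cnc12)C1CC1)C(=O)OCc1ccccc1`, gives 31.6% in this assay. The two numbers lie within the usual scatter of each other, so compound 2 cannot be set apart from compound 1 on these data; neither number stands out.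

Compound 3, `N=C(N)NCCC[C@H](NC(=O)CN(c1nc(Cl)nc2[nH]cnc12)C1CC1)C(=O)OCc1ccccc1`, has not yet been measured. It differs from compound 2 in one place: a group of 5 heavy atoms (2 carbon, 3 nitrogen; no ring) in place of a group of 2 heavy atoms (1 carbon, 1 sulfur; no ring), on a saturated chain carbon, three bonds along the chain from an amide-type nitrogen and a carbonyl carbon. Among the measured compounds shown here, no step between measured compounds of this kind exists to lean on, and the two measured numbers give no direction to follow.

In this assay the step from compound 2 to compound 3 is therefore expected to be small, a number 3.4 percentage points higher from compound 2 to compound 3 (within the scatter), not beyond the scatter in either direction. Compound 3 is estimated to give 35%, with a likely range from 20% to 50%, because compound 2 gives 31.6%.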

Compound 3, a percentage reported as activity, at one dose (the size of the read-out at that dose, not a potency): 10.2%
Beside the measured number, compound 3's estimate is 24.8 percentage points above it, and the stated range ends above it.
By their numbers in this assay, from the lowest: compound 3; then compounds 2 and 1 (each within the scatter of the next).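

In this assay, the two earlier compounds differ in more than one place and show no direction, but this single change shows that the position on the saturated chain carbon matters: the group of 5 heavy atoms in place of methylsulfanyl gives a number 21.4 percentage points lower from compound 2 to compound 3 (beyond the scatter) on the shared core. So, on this core and at the dose given, the new group is not a neutral swap for methylsulfanyl; compound 1 carries the same group but differs from compound 3 in more than one place, so it cannot test this finding. No measurement shown here explains the step.

Going by these compounds, it remains open whether the lower number comes from losing methylsulfanyl or from gaining the new group. A plain amine, a carboxylic acid or a longer sulfur-bearing chain at this place could help separate the two.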